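The source may hold more compounds than are shown below. What is called first, only, known or untested is meant among the compounds shown, and "the series" means these compounds.

Series notes. In an assay on HEK293 cells for agonist activity at transient receptor potential cation channel subfamily M member 8 (Homo sapiens), read by fluorescence and calcium flux, with a stated time of 15 min (on this read-out lower numbers stand for an effect already at smaller amounts and higher numbers for an effect only at larger amounts of compound), compound 1 `CCN(Cc1ccco1)C(=O)COc1ccc(C)cc1` gives 489 nM, compound 2 `Cc1ccc(OCC(=O)N(Cc2cccs2)c2ccnn2C)cc1` gives 422 nM and compound 3 `COc1ccc(OCC(=O)N(Cc2cccs2)c2ccn[nH]2)cc1` gives 3.7 nM. Among these three numbers compound 2 holds the second highest; its nearest neighbour is compound 1, whose number lies within the usual scatter of that of compound 2, while compound 3 stands far lower, beyond the scatter. Compound 2 and compound 3 differ in more than one place, so their gap cannot be tied to any single change. Compound 4 `Cc1ccc(OCC(=O)N(Cc2cccs2)c2ccncc2)cc1` is not yet measured; relative to compound 2 the change is pyridin-4-yl in place of 1-methyl-1H-pyrazol-5-yl on an amide-type nitrogen. Going by the values given here, no measured pair in the set isolates this change, and nothing here shows how the group on the amide-type nitrogen alone affects the read-out. Expected is therefore a small step in either direction, most likely not beyond the scatter. The estimated step is a 1.4-fold higher number from compound 2 to compound 4 (0.15 log units; within the scatter). For compound 4 the expected value in this assay is 600 nM, with a range from 120 nM to 3000 nM.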

Compound 4, half-maximal effective concentration: 52 nM
Estimate against measurement, compound 4: 12-fold (1.06 log units) above; the whole stated range lies above it.
By their numbers in this assay, from the lowest: compound 3; then compound 4; then compounds 2 and 1 (each within the scatter of the next).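

Unlike the earlier compounds, the pair of compound 2 and compound 4 isolates the group on the amide-type nitrogen: in this assay pyridin-4-yl in place of 1-methyl-1H-pyrazol-5-yl gives an 8.1-fold lower number from compound 2 to compound 4 (0.91 log units; beyond the scatter) and this step lies beyond the usual scatter. This position therefore responds to the ring it carries, even though the two rings have the same heavy-atom count and differ only in ring size and hetero atoms. Nothing available explains the step, so it cannot be assigned to either of those differences.

Open, as far as these compounds go, is whether the step follows ring size or the hetero atoms; phenyl or pyridin-3-yl on the same nitrogen would separate the two. Also open, from the compounds shown here alone, is whether pyridin-4-yl gives a similar step on other parts of the series, such as with the methoxy group of compound 3 in place of the methyl group.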